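Amide variation at the carbonyl: hydroxypyrrolidine in place of hydroxypropylamine

The compounds below may be only part of what the source reports. "The series", "measured", "known", "first", "only" and "open" are said of these compounds alone.

Compound 2 `COc1ccc(C#Cc2ccc(C(=O)NC(C)CO)cc2)cc1` carries a (1-(hydroxymethyl)ethyl)amino group on the carbonyl carbon of the shared core. In a functional assay on HEK293 cells for negative allosteric modulation of metabotropic glutamate receptor 2 (Rattus norvegicus), read by calcium flux, with a stated time of 2.5 min (on this read-out lower numbers stand for stronger inhibition and higher numbers for weaker inhibition), compound 2 gives > 30000 nM, which is a limit of the assay and not a number. Compound 1 `COc1ccc(C#Cc2ccc(C(=O)N3CCCC(OC)C3)cc2)cc1` carries a 3-methoxypiperidin-1-yl group on the same carbonyl carbon. In this assay compound 1 gives > 30000 nM, likewise a limit. The step that the two limits leave unreadable from compound 1 to compound 2 is therefore unreadable, since both values sit at the limit of > 30000 nM in this assay, at which 2 of the 2 values shown sit. Going by the values given here, compound 2 thus stands at the limit, together with the only other measured compound.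

Compound 3 `COc1ccc(C#Cc2ccc(C(=O)N3CC[C@H](O)C3)cc2)cc1` differs from compound 2 by 3-hydroxypyrrolidin-1-yl in place of (1-(hydroxymethyl)ethyl)amino on a carbonyl carbon. No measured step bears directly on this exchange; the single step shown, from compound 1 to compound 2, gives no size because the limit of > 30000 nM in this assay, at which 2 of the 2 values shown sit, covers both of its ends. Two amide variants at this carbonyl have so far stayed at the limit, so compound 3 is expected to remain there as well, and the step of a number no higher from compound 2 to compound 3 (the limit leaves the size open) is expected to be none beyond the scatter. For compound 3 in this assay the estimate is 30000 nM, with a range from 10000 nM to 100000 nM, most likely again reported only as a limit.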

Compound 3, half-maximal inhibitory concentration: > 30000 nM
Compound 3: only a limit was reported; the forecaster's own chance of this, stated with the estimate: 80%; the middle value lies on the limit itself.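

No step can be read among compound 1, compound 2 and compound 3 in this assay, since all three values are limits of the assay and not numbers: the limit of > 30000 nM in this assay, at which 3 of the 3 values shown sit.

The compounds shown leave open how far these three amides differ from one another, and whether any amide group on this carbonyl carbon gives a measurable inhibition.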